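Cytotoxicity of thienopyridine amides on Huh-7 cells

A few compounds are considered here, and "the series" means these few. Any claim that something is new, unique, unknown or untested is made for them only; others in the source may bear on it.

Measured compounds:
compound 1, `Nc1c(C(=O)O)sc2nc(-c3ccccc3)cc(C(F)(F)F)c12`: > 20000 nM
compound 2, `CN(C)C(=O)c1sc2nc(-c3ccccc3)cc(C(F)(F)F)c2c1N`: > 20000 nM
compound 3, `Nc1c(C(=O)NC2CCCC2)sc2nc(-c3ccccc3)cc(C(F)(F)F)c12`: > 20000 nM

In an ADME assay on Huh-7 cells (Homo sapiens) for cytotoxicity, read by MTT assay, with a stated time of 72 h (a lower number here means that less compound is tolerated, a higher number that more compound is tolerated), compound 1 gives > 20000 nM, which is a limit of the assay and not a number. Compound 2 likewise gives > 20000 nM, a limit. Compound 3 gives > 20000 nM, again a limit. Each of the three steps between them, a step that the two limits leave unreadable from compound 1 to compound 2, a step that the two limits leave unreadable from compound 1 to compound 3 and a step that the two limits leave unreadable from compound 2 to compound 3, is therefore unreadable in size, since (the limit of > 20000 nM in this assay, at which 3 of the 3 values shown sit).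

Compound 4, `Nc1c(C(=O)NCc2cccs2)sc2nc(-c3ccccc3)cc(C(F)(F)F)c12`, is not yet measured. Its change from compound 3 is (thiophen-2-yl)methyl in place of cyclopentyl on an amide-type nitrogen. For the measured compounds named here, no measured step bears on this change directly; the two steps into amides, a step that the two limits leave unreadable from compound 1 to compound 3 and a step that the two limits leave unreadable from compound 2 to compound 3, are both unreadable, and nothing among the three compounds shows a change in tolerance at all. The expectation for compound 4 is therefore no step beyond the scatter, a step that the limit leaves unreadable from compound 3 to compound 4, and compound 4 is estimated at 25000 nM with a range from 12000 nM to 60000 nM, most likely reported again only as a limit.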

Compound 4, half-maximal cytotoxic concentration: > 20000 nM
Compound 4 ended at the assay's limit; the forecaster's own chance of this, stated with the estimate: 80%; the middle value does not contradict the limit.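

For the compounds shown here, compound 4, like compound 1, compound 2 and compound 3, sits at a limit and not a number in this assay, so no step among the four can be read: the limit of > 20000 nM in this assay, at which 4 of the 4 values shown sit. Which change to the amide or the shared core, if any, would give a measurable value remains open.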